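A few compounds are considered here, and "the series" means these few. Any claim that something is new, unique, unknown or untested is made for them only; others in the source may bear on it.

Compound 1 `ClCc1cccc(Cn2cnc3ncnc(Cl)c32)c1` and compound 2 `ClCc1ccccc1Cn1cnc2ncnc(Cl)c21` share the same atoms joined differently; the difference between the two cores is not broken down here. In a functional assay on IGROV-1 cells (Homo sapiens) for cytotoxicity, read by sulforhodamine B assay, with a stated time of 48 h (a higher number here means that more compound is tolerated, a lower number that less compound is tolerated), compound 1 gives 5880 nM. In this assay compound 2 gives only a limit, > 100000 nM, which is the limit (the limit of > 100000 nM in this assay, at which 1 of the 3 values shown sits). Compound 3 `ClCc1cccc(Cn2cnc3nc(Cl)nc(Cl)c32)c1` differs from compound 1 by chloro in place of hydrogen on an aromatic carbon, and in this assay compound 3 gives 55000 nM; the step is a 9.4-fold higher number from compound 1 to compound 3 (0.97 log units; beyond the scatter). Compound 4 `ClCc1ccccc1Cn1cnc2nc(Cl)nc(Cl)c21` has not yet been measured; it differs from compound 2 by chloro in place of hydrogen on an aromatic carbon, the same change as that from compound 1 to compound 3. Since compound 2 already sits at the limit, the expected step that the limit leaves unreadable from compound 2 to compound 4 can only be placed beside the earlier one by assumption, resting on the step of a 9.4-fold higher number from compound 1 to compound 3 (0.97 log units; beyond the scatter) and on the limit of compound 2, > 100000 nM. For compound 4 the estimate is 300000 nM, between 100000 nM and 1000000 nM, most likely reported again only as a limit in this assay.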

Compound 4, concentration lethal to 50% of the cells: 9540 nM
Estimate against measurement, compound 4: 31-fold (1.50 log units) above, and the stated range ends above it.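

In this assay, chloro in place of hydrogen on an aromatic carbon gives an at least 10-fold lower number from compound 2 to compound 4 (1.02 log units; beyond the scatter), so the change does not carry over unchanged from the core of compound 1 to the core of compound 2: the same change on two cores in this assay, a 9.4-fold higher number (0.97 log units; beyond the scatter) from compound 1 to compound 3 and an at least 10-fold lower number (1.02 log units; beyond the scatter) from compound 2 to compound 4, at least 98-fold (1.99 log units) apart, beyond the scatter of two such steps

On these data alone, compound 2 gives > 100000 nM, which is a limit and not a number, so the step from it has only a lower bound on its size and its full size stays unknown.

The two pairs show that, in these two cores, the outcome of the change differs with the core, but they do not show why it differs or how the same change would run on any further core.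

As far as these compounds go, whether an amine or a methyl group at the same ring carbon would follow the pattern of either core remains open. So does whether a longer chain in place of the chloromethyl group would leave the two cores as far apart in this assay.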